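Compound 3 to compound 4: trifluoromethyl gives way to amino

The source may report more compounds than this note shows. Statements on the series, on what has been measured and on what is new or still open speak of the compounds shown alone.

Measured so far in an ADME assay on microsomes from liver (Homo sapiens) for metabolic stability, read by LC-MS (a higher number here means faster removal of the compound, a lower number slower removal), as follows
- compound 1 `FC(F)(F)c1nccc(N[C@H]2CC[C@@H](Nc3ccc4nncn4n3)CC2)n1` gives < 3 mL.min-1.g-1 as a limit
- compound 2 `Cc1nnc2ccc(N[C@H]3CC[C@@H](Nc4ccnc(C(F)(F)F)n4)CC3)nn12` gives < 3 mL.min-1.g-1 as a limit
- compound 3 `FC(F)(F)c1nccc(N[C@H]2CC[C@@H](Nc3ccc4nnc(C(F)(F)F)n4n3)CC2)n1` gives < 3 mL.min-1.g-1 as a limit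

Compound 3 stands at < 3 mL.min-1.g-1 as a limit of the assay and not as a number. The two other results are limits too, so all three compounds share the limit of < 3 mL.min-1.g-1 in this assay, at which 3 of the 3 values shown sit, and no order among them can be read. Compound 4 `Nc1nnc2ccc(N[C@H]3CC[C@@H](Nc4ccnc(C(F)(F)F)n4)CC3)nn12` carries amino in place of trifluoromethyl on an aromatic carbon, a change counted as amino in place of trifluoromethyl on an aromatic carbon and sited between two ring nitrogen atoms. The steps at that same place bear on it, yet a step that the two limits leave unreadable from compound 1 to compound 2 and a step that the two limits leave unreadable from compound 1 to compound 3 and a step that the two limits leave unreadable from compound 2 to compound 3 give no size to carry over. Hydrogen, methyl and trifluoromethyl there all stay at the limit of < 3 mL.min-1.g-1 in this assay, at which 3 of the 3 values shown sit, and so no shift beyond the scatter is expected. The expected move is a step that the limit leaves unreadable from compound 3 to compound 4 with no direction favoured. For compound 4 the estimated value is 2.5 mL.min-1.g-1 with an expected range from 1 mL.min-1.g-1 to 6 mL.min-1.g-1 should the assay report a number at all.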

Compound 4, intrinsic clearance in microsomes: < 3 mL.min-1.g-1
Compound 4 gave a limit, no number; the forecaster's own chance of this, stated with the estimate: 70%; the middle value is on the limit's open side.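

In this assay compound 4 gives < 3 mL.min-1.g-1, which is a limit of the assay and not a number. Among these compounds, no step from compound 1, compound 2 or compound 3 to compound 4 can be read: the limit of < 3 mL.min-1.g-1 in this assay, at which 4 of the 4 values shown sit. The compounds shown leave open whether hydrogen, methyl, trifluoromethyl and amino on that aromatic carbon differ at all in this assay.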